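Compound 2 to Compound 4: Cyclopentyl Replaces Isopropyl

The compounds below may be only part of what the source reports. "The series", "measured", "known", "first", "only" and "open" are said of these compounds alone.

In an ADME assay on A549 cells (Homo sapiens) for cytotoxicity, read by resazurin assay, with a stated time of 48 h (a lower number here means that less compound is tolerated, a higher number that more compound is tolerated), compound 1 (`CCNc1ccc(NC(=O)c2cc(Cl)ccc2O)c(Cl)c1`) gives 30200 nM. Compound 2 (`CC(C)CNc1ccc(NC(=O)c2cc(Cl)ccc2O)c(Cl)c1`) gives 60000 nM, which is within the scatter of compound 1. Compound 3 (`CCCCCCCCC(C)Nc1ccc(NC(=O)c2cc(Cl)ccc2O)c(Cl)c1`) gives 21900 nM, which lies beyond the scatter from compound 2. Compound 4 (`O=C(Nc1ccc(NCC2CCCC2)cc1Cl)c1cc(Cl)ccc1O`) differs from compound 2 as follows: cyclopentyl in place of isopropyl on a saturated chain carbon bound to a nitrogen on an aromatic ring. This places cyclopentyl in place of isopropyl on a saturated chain carbon bound to a nitrogen on an aromatic ring. Two measured changes at this chain bear on it: a 2.0-fold higher number from compound 1 to compound 2 (0.30 log units; within the scatter) and a 1.4-fold lower number from compound 1 to compound 3 (0.14 log units; within the scatter). Both lie within the scatter, so no step beyond the scatter is expected in this assay. The expected step is a 1.5-fold lower number from compound 2 to compound 4 (0.18 log units; within the scatter), a slight lowering at most. For compound 4 the estimated value is 40000 nM, with an expected range of 18000 nM to 85000 nM.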

Compound 4, half-maximal cytotoxic concentration: 21500 nM
Beside the measured number, compound 4's estimate is 1.9-fold (0.27 log units) above it; the measured number falls inside the stated range.
By their numbers in this assay, from the lowest: compounds 4, 3, 1 and 2 (each within the scatter of the next, the first and the last beyond it).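

In this assay, the change to a carbon-only ring at this place gives a 2.8-fold lower number from compound 2 to compound 4 (0.45 log units; beyond the scatter), the first listed step at this chain to pass the scatter. The same group set against the smaller chain gives only a 1.4-fold lower number from compound 1 to compound 4 (0.15 log units; within the scatter), so compound 2 alone stands apart from compound 4, while compound 1 does not. Nothing available explains why this step is larger than the other. As far as these compounds go, whether a cyclohexyl, phenyl or piperidinyl group at this place would follow compound 4 or compound 2 remains open.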